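Moving the Carboxyphenoxy Ether and Adding a Methyl

A few compounds are considered here, and "the series" means these few. Any claim that something is new, unique, unknown or untested is made for them only; others in the source may bear on it.

Of the compounds shown here, three sharing one core have been measured in a functional assay on HEK293 cells for agonist activity at Bile acid receptor (Homo sapiens); a lower number here means a smaller maximal response, a higher number a larger maximal response. Compound 1 `CN(Cc1ccc(C(=O)O)cc1)c1ccc(OCc2c(-c3c(Cl)cccc3Cl)noc2C2CC2)nc1C(F)(F)F` gives 81% in this assay. Compound 2 `CC(c1ccc(OCc2c(-c3c(Cl)cccc3Cl)noc2C2CC2)nc1C(F)(F)F)N(C)c1ccc(C(=O)O)cc1` gives 55%. Compound 3 `O=C(O)c1ccccc1OCc1ccc(OCc2c(-c3c(Cl)cccc3Cl)noc2C2CC2)nc1C(F)(F)F` gives 63%, the second highest of the three numbers; its nearest neighbour is compound 2, within the usual scatter, and its furthest is compound 1, with the change a number 18 percentage points lower from compound 1 to compound 3 (beyond the scatter), a modest step beyond the scatter.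

Compound 4 `CC(Oc1cccc(C(=O)O)c1)c1ccc(OCc2c(-c3c(Cl)cccc3Cl)noc2C2CC2)nc1C(F)(F)F` differs from compound 3 in one place: 1-(3-carboxyphenoxy)ethyl in place of (2-carboxyphenoxy)methyl on an aromatic carbon. For the measured compounds named here, the only measured step in this assay, the one from compound 1 to compound 3, swaps an amino-linked group for an ether-linked one and does not repeat this change. Going by the values given here, what the numbers of compound 1 and compound 2 show is that an ethyl link in place of a methylene link accompanied a lower maximal response, though no single-point step between them is given. On that basis a modest drop is expected for compound 4, by about a number 13 percentage points lower from compound 3 to compound 4 (beyond the scatter). Compound 4 is therefore estimated to reach 50% in this assay, between 35% and 66%.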

Compound 4, largest response reached (reported as efficacy), in percent of the reference or control that the assay uses: 50%
For compound 4 middle estimate and measured number coincide at the digits printed; measured number inside the range.
By their numbers in this assay, from the lowest: compounds 4, 2 and 3 (each within the scatter of the next, the first and the last beyond it); then compound 1.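

In this assay, placing 1-(3-carboxyphenoxy)ethyl on this aromatic carbon, ortho to a trifluoromethyl group, gives a number 13 percentage points lower from compound 3 to compound 4 (beyond the scatter), so the ether-linked group also responds to a change in its own structure and not only to the swap of an amino link for an ether link. With the substituted chain carbon kept, exchanging (4-carboxyphenyl)(methyl)amino for 3-carboxyphenoxy gives a number 5 percentage points lower from compound 2 to compound 4 (within the scatter), so the amino and ether links cannot be told apart on that carbon, whereas replacing (4-carboxybenzyl)(methyl)amino with the new group gives a number 31 percentage points lower from compound 1 to compound 4 (beyond the scatter), the largest step shown at this position. No measurement is available that bears on the reason for these steps.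

Going by these compounds, the step from (2-carboxyphenoxy)methyl to 1-(3-carboxyphenoxy)ethyl alters both the chain carbon and the place of the carboxylic acid on the ring, so the share of each in the lower number remains open. Also open, on these data alone, is how 1-(2-carboxyphenoxy)ethyl, (3-carboxyphenoxy)methyl or an amide in place of the carboxylic acid would behave at this position.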